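The compounds below may be only part of what the source reports. "The series", "measured", "known", "first", "only" and "open" are said of these compounds alone.

Measured so far:
compound 1 `O=C(NNc1nncc2ccccc12)C1CC1c1ccc(OCC(F)(F)F)cc1`: 29000 nM
compound 2 `O=C(NNC(=O)C1CC1c1ccc(OCC(F)(F)F)cc1)c1ccncc1`: 81000 nM
compound 3 `COc1ccc(C2CC2C(=O)NNC(=O)c2ccncc2)cc1`: "not determined" (no result reported)

In a functional assay on SK-MEL cells (Homo sapiens) for inhibition, read by MTT assay, with a stated time of 72 h (a lower number here means a stronger inhibitor, a higher number a weaker inhibitor), compound 1 gives 29000 nM, the lower of the two numbers available, while compound 2 gives 81000 nM, a gap that lies beyond the usual scatter. For compound 3 the entry in this assay is "not determined" (no result reported). Compound 4 `O=C(NNc1nncc2ccccc12)C1CC1c1ccc(OC(F)(F)F)cc1` has not yet been measured. It differs from compound 1 in a single place: trifluoromethyl in place of 2,2,2-trifluoroethyl on an oxygen on an aromatic ring. Among the compounds with values here, no measured pair in this set shows the same change, so nothing here tells how large its effect is. Because compound 1 gives 29000 nM and the two structures are otherwise the same, the expected step is a 1.0-fold higher number from compound 1 to compound 4 (0.01 log units; within the scatter), which is none beyond the scatter. Compound 4 is therefore estimated at 30000 nM, with a range from 10000 nM to 90000 nM.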

Compound 4, half-maximal inhibitory concentration: 29000 nM
Beside the measured number, compound 4's estimate is 1.0-fold (0.01 log units) above it; the range from low to high includes it.
By their numbers in this assay, from the lowest: compounds 1 and 4 (each within the scatter of the next); then compound 2.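

In this assay, putting trifluoromethyl in place of 2,2,2-trifluoroethyl on the oxygen gives no change at the digits printed from compound 1 to compound 4 (within the scatter), so the shared core tolerates this shorter group here with no shift that can be read. Within the data shown here, this is the first pair in the set that differs in one place, and it gives this change a measured size. No evidence is available to explain the result. Still open, from the compounds shown here alone, is whether ethyl, a longer chain such as butyl, or a chain ending in an amine on this oxygen would move the number beyond the scatter.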